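Working notes: from compound 2 to compound 4

The compounds below may be only part of what the source reports. "The series", "measured", "known", "first", "only" and "open" are said of these compounds alone.

Measured in a physicochemical assay for lipophilicity, read by LC-MS, using the shake flask method, in phosphate buffer, measured as octanol-water partition, with a stated time of 2 h, at pH 7.4; on this read-out higher numbers stand for higher lipophilicity and lower numbers for lower lipophilicity:
Compound 1 `O=C(O)c1cncc(-n2cc(CO[C@H]3O[C@H](CO)[C@@H](O)[C@H](O)[C@@H]3O)nn2)c1`: "not determined" (no result reported)
Compound 2 `OC[C@H]1O[C@H](n2cc(-c3ccccc3)nn2)[C@@H](O)[C@@H](O)[C@@H]1O`: 0.21
Compound 3 `OC[C@H]1O[C@H](n2cc(-c3ccc(C(F)(F)F)cc3)nn2)[C@@H](O)[C@@H](O)[C@@H]1O`: 1.45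

Compound 2 holds the lower of the two numbers, and compound 1 offers no number for comparison. Compound 4 `OC[C@H]1O[C@H](n2cc(COc3ccccc3)nn2)[C@@H](O)[C@@H](O)[C@@H]1O` has phenoxymethyl in place of phenyl on an aromatic carbon. For the measured compounds named here, the one measured step, a number 1.24 log units higher from compound 2 to compound 3 (beyond the scatter), came with trifluoromethyl in place of hydrogen on an aromatic carbon. Going by the values given here, that is a different change, so it sets no size for this one, and no measured step covers this exchange. The expected result in this assay is a number 0.09 log units higher from compound 2 to compound 4 (within the scatter), a small upward step at most, possibly none beyond the scatter. For compound 4 the estimate is 0.3, with an expected range of -0.2 to 0.8.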

Compound 4, distribution coefficient: -0.18
The estimate for compound 4 lay 0.48 log units above the measured number, and the stated range covers the measured number.
By their numbers in this assay, from the lowest: compound 4; then compound 2; then compound 3.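

In this assay this aromatic carbon of the five-membered aromatic ring with 3 nitrogen does register the exchange, with a number 0.39 log units lower from compound 2 to compound 4 (beyond the scatter). Phenoxymethyl brings 8 heavy atoms against 6 and 1 hydrogen-bond acceptor against 0, and the number goes down, whereas trifluoromethyl in place of hydrogen gave a number 1.24 log units higher from compound 2 to compound 3 (beyond the scatter). No measurement at hand explains the drop.

Whether the oxygen alone accounts for the step stays open, since a benzyl group or a longer carbon chain at this position would separate oxygen from chain length. Also open, as far as these compounds go, is whether trifluoromethyl on the phenoxymethyl ring would repeat its upward step.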